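From isopropyl to cyclohexyl: working notes on compound 3

The compounds below may be only part of what the source reports. "The series", "measured", "known", "first", "only" and "open" are said of these compounds alone.

Measured in an ADME assay on MT4 cells (Homo sapiens) for cytotoxicity, read by MTT assay, with a stated time of 4 days; a lower number here means that less compound is tolerated, a higher number that more compound is tolerated:
- Compound 1 `CCN(C)c1nc(Cc2c(F)cccc2F)c(C)c(=O)[nH]1`: > 85000 nM
- Compound 2 `Cc1c(Cc2c(F)cccc2F)nc(N(C)C(C)C)[nH]c1=O`: 79000 nM

Compound 1 gives > 85000 nM, which is a limit of the assay and not a number. Going by the values given here, compound 2, at 79000 nM, holds the only actual number in this assay, so it cannot yet be ranked within a wider spread of values.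

Compound 3 `Cc1c(Cc2c(F)cccc2F)nc(N(C)C2CCCCC2)[nH]c1=O` carries cyclohexyl in place of isopropyl on a nitrogen on an aromatic ring.

Among the compounds with values here, one measured step bears on this change: an at least 1.0-fold lower number from compound 1 to compound 2 (0.03 log units; that floor lies within the scatter). There, methyl replaces hydrogen on a saturated chain carbon bound to that same kind of nitrogen. Its size is only a floor and lies within the scatter, so it gives weak guidance for a change that brings in a ring. On this evidence, no shift beyond the scatter is expected, though a lower number remains the likelier direction and the range stays wide.

The expected step is a 1.4-fold lower number from compound 2 to compound 3 (0.16 log units; within the scatter).

In this assay, the estimate for compound 3 is 55000 nM, with an expected range of 18000 nM to 120000 nM.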

Compound 3, half-maximal cytotoxic concentration: > 72000 nM
Compound 3: no number, only a limit; the forecaster's own chance of this, stated with the estimate: 20%; middle value at least 1.3-fold (0.11 log units) away from the limit.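

In this assay compound 3 gives > 72000 nM, which is a limit of the assay and not a number, so neither the step from compound 2 to compound 3 nor the step from compound 1 to compound 3 can be read. The compounds shown leave open whether cyclohexyl in place of isopropyl moves the number at all.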